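This account rests on a few compounds, and the source may have more. Where it says the series, first, only, none or still open, it means among the compounds named here.

Measured compounds:
compound 1 `N#Cc1c(Cl)nc(SCC(=O)Nn2c(COc3ccc(Cl)cc3Cl)nc3ccccc3c2=O)nc1-c1ccc(O)cc1` gives 73.7% in a functional assay on the whole organism (strain albino) for inhibition, with Rattus norvegicus as the target, read by paw edema, with stated times of 1 h and 3 h, at a dose of 100 mg/kg by the oral route; on this read-out lower numbers stand for a weaker effect and higher numbers for a stronger effect at the one dose given
compound 2 `N#Cc1c(Nc2ccccc2)nc(SCC(=O)Nn2c(COc3ccc(Cl)cc3Cl)nc3ccccc3c2=O)nc1-c1ccccc1` gives 78.1% in this assay
compound 3 `N#Cc1c(Nc2ccccc2)nc(SCC(=O)Nn2c(COc3ccc(Cl)cc3Cl)nc3ccccc3c2=O)nc1-c1ccc(Cl)cc1` gives 56.1% in this assay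

Compound 3 stands lowest of the three numbers; compound 1 is the nearest to it and compound 2 the furthest, both beyond the scatter. Among the measured compounds shown here, the only single-point step measured is a number 22 percentage points lower from compound 2 to compound 3 (beyond the scatter), a modest loss.

Compound 4 `N#Cc1c(Nc2ccccc2)nc(SCC(=O)Nn2c(COc3ccc(Cl)cc3Cl)nc3ccccc3c2=O)nc1-c1ccc(O)cc1` is the next member, unmeasured so far. Against compound 3 the change is hydroxy in place of chloro on an aromatic carbon. For the measured compounds named here, no measured pair shows hydroxy in place of chloro at this position directly. What bears on it is that the chloro entering from compound 2 to compound 3 cost ground, and that compound 1, which carries the same hydroxy group on that ring though it differs elsewhere, gives 73.7%. Compound 4 is therefore expected to recover toward the range of compound 1 and compound 2, the step of a number 15.9 percentage points higher from compound 3 to compound 4 (beyond the scatter) being an expected gain beyond the scatter. The estimate for compound 4 in this assay is 72%, with a range from 58% to 84%.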

Compound 4, a percentage reported as inhibition, in the whole organism at one dose (the size of the read-out at that dose, not a potency): 91.2%
Compound 4: middle estimate off by 19.2 percentage points, on the low side, outside the stated range (above it).
By their numbers in this assay, from the lowest: compound 3; then compounds 1 and 2 (each within the scatter of the next); then compound 4.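

In this assay, the change from 4-chlorophenyl to 4-hydroxyphenyl gives a large gain (a number 35.1 percentage points higher from compound 3 to compound 4 (beyond the scatter)), and hydroxy in place of hydrogen also gains (a number 13.1 percentage points higher from compound 2 to compound 4 (beyond the scatter)), so this position, which had shown only a loss with chloro, can also raise the read-out. With the hydroxy group held, anilino in place of chloro on the other aromatic carbon also gains (a number 17.5 percentage points higher from compound 1 to compound 4 (beyond the scatter)), so the read-out responds to the group at that second place as well. No measurement available here accounts for these differences.

A methoxy or an amino group at the same place would test whether the gain is specific to hydroxy. These results show only a stronger or weaker effect at the single dose given, and the gain from hydroxy is shown only alongside anilino, not alongside chloro.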